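A few compounds are considered here, and "the series" means these few. Any claim that something is new, unique, unknown or untested is made for them only; others in the source may bear on it.

Series notes, growth inhibition on the lung cancer line. Compound 1 `COc1ccccc1-c1cc(-c2ccc([N+](=O)[O-])cc2)[nH]n1` and compound 2 `COc1ccccc1-c1cc(-c2ccccc2-c2ccccc2)n[nH]1` share the core and are read in a functional assay on NCI-H460 cells (Homo sapiens) for inhibition, read by MTT assay, with a stated time of 48 h; a lower number here means a stronger inhibitor of growth, a higher number a weaker inhibitor of growth. In this assay, going by the values given here, compound 1 gives 20500 nM, while compound 2 gives 9100 nM; the two differ in several places at once, so only the pair of numbers can be read, not a single step. Compound 1 carries the highest number of the two measured here, with compound 2 lying beyond the scatter below it.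

Compound 3 `O=[N+]([O-])c1ccc(-c2cc(-c3ccccc3-c3ccccc3)n[nH]2)cc1` has not yet been measured. Relative to compound 1 the change is phenyl in place of methoxy on an aromatic carbon; the place is an aromatic carbon of a six-membered aromatic ring of carbon only, ortho to a large group.

Among the compounds with values here, no measured step covers this change. Within the data shown here, the only guide is that the same phenyl-bearing ring as in compound 3, alongside an unsubstituted phenyl on the core, is carried by compound 2, which shows 9100 nM. On that basis the step is expected to be a modest decrease in number, a 2.1-fold lower number from compound 1 to compound 3 (0.31 log units; beyond the scatter), and the value for compound 3 in this assay is estimated at 10000 nM, within a range of 4000 nM to 25000 nM.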

Compound 3, concentration for 50% growth inhibition: 2700 nM
Compound 3: middle estimate off by 3.7-fold (0.57 log units), on the high side; the whole stated range lies above it.
By their numbers in this assay, from the lowest: compound 3; then compound 2; then compound 1.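

In this assay, going by these compounds alone, this aromatic carbon, ortho to a large group, proves sensitive to substitution: phenyl in place of methoxy gives a 7.6-fold lower number from compound 1 to compound 3 (0.88 log units; beyond the scatter) and is the only single-place step so far. The earlier pair differed in several places at once, so it could not show that this one change, with the rest of the molecule held fixed, moves the number beyond the scatter. The step also shows that the larger aromatic group, which brings a whole six-membered ring where methoxy stood, costs no growth inhibition at this place, though no measurement on these compounds accounts for the size of the step.

Going by these compounds, what stays open is whether the lower number belongs to phenyl itself or would also follow from other groups on this carbon, such as an amine, a carboxylic acid or a longer alkoxy chain. It is also unsettled whether the step keeps its size when the nitro group on the other aromatic ring is replaced, or in any cell line other than this one.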